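A few compounds are considered here, and "the series" means these few. Any claim that something is new, unique, unknown or untested is made for them only; others in the source may bear on it.

In an in vitro assay on HEK385-7 cells for displacement of a labelled ligand from prostaglandin D2 receptor 2 (Homo sapiens) (on this read-out higher numbers stand for weaker inhibition and lower numbers for stronger inhibition), compound 3 `O=C(O)Cc1sc(C(c2ccc(F)cc2)c2ccc(F)cc2)nc1-c1ccco1` gives 18 nM, the lowest of the three numbers recorded. Compound 1 `N#Cc1cc(-c2nc(C(c3ccc(F)cc3)c3ccc(F)cc3)sc2CC(=O)O)ccc1F` gives 57 nM and compound 2 `NS(=O)(=O)c1ccc(-c2nc(C(c3ccc(F)cc3)c3ccc(F)cc3)sc2CC(=O)O)cc1` gives 1500 nM; the changes were a 3.2-fold lower number from compound 1 to compound 3 (0.50 log units; beyond the scatter) and an 83-fold lower number from compound 2 to compound 3 (1.92 log units; beyond the scatter), so the group at this position has moved the numbers strongly. Compound 4 `O=C(O)Cc1sc(C(c2ccc(F)cc2)c2ccc(F)cc2)nc1-c1ccoc1` differs from compound 3 by furan-3-yl in place of furan-2-yl on an aromatic carbon. Among the measured compounds shown here, no measured step exchanges one furan for another; the two steps that touch this position swap a 3-cyano-4-fluorophenyl or a 4-sulfamoylphenyl for furan-2-yl and say nothing about furan-3-yl. A step of at most modest size is therefore expected in this assay, in either direction. Compound 4 is expected to give about 30 nM, between 10 nM and 100 nM. This estimate is expected to amount to a 1.7-fold higher number from compound 3 to compound 4 (0.22 log units; within the scatter).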

Compound 4, half-maximal inhibitory concentration: 14 nM
Beside the measured number, compound 4's estimate is 2.1-fold (0.33 log units) above it, within the range that was stated.
By their numbers in this assay, from the lowest: compounds 4 and 3 (each within the scatter of the next); then compound 1; then compound 2.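

In this assay the exchange of furan-2-yl for furan-3-yl gives a 1.3-fold lower number from compound 3 to compound 4 (0.11 log units; within the scatter) and so the two ways of attaching the furan cannot be told apart at this position. Furan-3-yl gives a 4.1-fold lower number from compound 1 to compound 4 (0.61 log units; beyond the scatter) and a 110-fold lower number from compound 2 to compound 4 (2.03 log units; beyond the scatter) at the same position, so the advantage over those two substituted phenyl groups holds for either furan.

Going by these compounds, whether thiophen-2-yl or an unsubstituted phenyl would match the furans remains open. Nothing measured here explains why the two furans behave alike.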